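Swapping the furan of compound 1 for a sulfonamide-bearing phenyl

This account rests on a few compounds, and the source may have more. Where it says the series, first, only, none or still open, it means among the compounds named here.

Of the compounds shown here, three that share one core have been measured in an in vitro assay on HEK385-7 cells for displacement of a labelled ligand from prostaglandin D2 receptor 2 (Homo sapiens); on this read-out higher numbers stand for weaker inhibition and lower numbers for stronger inhibition. Compound 1, `O=C(O)Cc1sc(C(c2ccc(F)cc2)c2ccc(F)cc2)nc1-c1ccco1`, gives 18 nM. Compound 2, `O=C(O)Cc1sc(C(c2ccccc2)c2ccc(Cl)cc2)nc1-c1ccc(Cl)cc1`, gives 45 nM, and compound 3, `O=C(O)Cc1sc(C(c2ccccc2)c2ccccc2)nc1-c1ccc(F)c(F)c1`, gives 4.1 nM. Among these three numbers compound 1 stands second highest: compound 2 sits at a higher number, beyond the scatter, while compound 3 sits at a lower number, also beyond the scatter.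

The next compound, compound 4, is `CS(=O)(=O)Nc1cccc(-c2nc(C(c3ccc(F)cc3)c3ccc(F)cc3)sc2CC(=O)O)c1`. It differs from compound 1 in one place: 3-(methanesulfonamido)phenyl in place of furan-2-yl on an aromatic carbon. For the measured compounds named here, no measured pair in this set shows this exact change, so there is no step to lean on. What the set does show is that compounds 2 and 3, which carry a six-membered aromatic ring of carbon only in the same place, span both sides of compound 1. Taking the result of compound 3 as the closer guide, the step from compound 1 to compound 4 in this assay is expected to be a modest one toward a lower number, a 1.8-fold lower number from compound 1 to compound 4 (0.26 log units; within the scatter), with a wide range. Compound 4 is therefore estimated at 10 nM, within 3 nM to 40 nM.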

Compound 4, half-maximal inhibitory concentration: 40 nM
Beside the measured number, compound 4's estimate is 4.0-fold (0.60 log units) below it; the measured number falls inside the stated range.
By their numbers in this assay, from the lowest: compound 3; then compound 1; then compounds 4 and 2 (each within the scatter of the next).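

In this assay, for the compounds shown here, replacing furan-2-yl with 3-(methanesulfonamido)phenyl gives a 2.2-fold higher number from compound 1 to compound 4 (0.35 log units; beyond the scatter), the first step in this set in which this position alone changes. It shows that inhibition responds to the group carried here, next to the ring nitrogen and next to the ring atom bearing the carboxymethyl group, yet a group of 11 heavy atoms in place of one of 5 moves the number only modestly. Nothing available here explains this shift.

The step combines a change of ring with the addition of the methanesulfonamido group, and a plain phenyl on the core of compound 1 would separate those two parts. From the compounds shown here alone, whether an amine or a carboxylic acid in place of the methanesulfonamido group would give a similar number remains open.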